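Adding a Carboxy Group to the Core of Compound 1

The compounds below may be only part of what the source reports. "The series", "measured", "known", "first", "only" and "open" are said of these compounds alone.

Compound 1 `CC1CC/C(=N\Nc2cccc(C(=O)O)c2)c2nccc(=O)n21`: > 100 umol/kg
Compound 2 `O=C(O)c1cnc2n(c1=O)CCC/C2=N\Nc1ccccc1`: 31.6 umol/kg

Both compounds were tested in a functional assay on the whole organism for inhibition, with Rattus norvegicus as the target; on this read-out lower numbers stand for an effect already at smaller amounts and higher numbers for an effect only at larger amounts of compound. Compound 1 reaches only a limit there, > 100 umol/kg (the limit of > 100 umol/kg in this assay, at which 1 of the 2 values shown sits). Compound 2, which carries a carboxy on the core, gives 31.6 umol/kg in this assay. Compound 3 `CC1CC/C(=N\Nc2cccc(C(=O)O)c2)c2ncc(C(=O)O)c(=O)n21` differs from compound 1 by carboxy in place of hydrogen on an aromatic carbon. Among the measured compounds shown here, no measured step joins the two. Because compound 2 gives 31.6 umol/kg, a gain beyond the scatter is expected for the new compound. The expected step is an at least 2.5-fold lower number from compound 1 to compound 3 (0.39 log units; beyond the scatter). Compound 3 is estimated at 40 umol/kg, between 15 umol/kg and 150 umol/kg.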

Compound 3, dose for 50% inhibition: 26.6 umol/kg
Compound 3: middle estimate off by 1.5-fold (0.18 log units), on the high side, within the range that was stated.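

On the core of compound 1, carboxy on this aromatic carbon, two atoms from the ring nitrogen, gives a directly readable gain in this assay: an at least 3.7-fold lower number from compound 1 to compound 3 (0.57 log units; beyond the scatter). The change therefore lowers the number beyond the scatter even with the second carboxy already present on the compound. The full size of the step remains unknown, since compound 1 reaches only a limit: the limit of > 100 umol/kg in this assay, at which 1 of the 3 values shown sits.

As far as these compounds go, whether the gain requires the carboxy itself remains open. A methyl ester, a primary amide or a tetrazole at this aromatic carbon could answer that.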